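The source may hold more compounds than are shown below. What is called first, only, known or untested is meant among the compounds shown, and "the series" means these compounds.

Going by the values given here, compound 2, `CC(=O)N[C@@H]1CCC[C@H](C(=O)Nc2cc(-c3cnn4c3CC(C)(C)C4)c(Cl)cn2)C1`, is the one compound here with a number in an ADME assay on cells (Hepatocyte, Homo sapiens) for metabolic stability, using equilibrium dialysis; on this read-out higher numbers stand for fast clearance and lower numbers for slow clearance: compound 2 gives 3.5 uL/min. Compound 1, `CC(=O)N[C@@H]1CCC[C@H](C(=O)Nc2cc(-c3cnn(C)c3C)c(Cl)cn2)C1`, reaches only a limit of this assay, < 1 uL/min, as stated in the limit of < 1 uL/min in this assay, at which 1 of the 2 values shown sits. The step of an at least 3.5-fold higher number from compound 1 to compound 2 (0.54 log units; beyond the scatter) changes a group on an aromatic carbon. Compound 3, `CC1(C)Cc2c(-c3cc(NC(=O)[C@H]4C[C@@H](O)C4)ncc3Cl)cnn2C1`, differs from compound 2 at another place: 3-hydroxycyclobutyl in place of 3-acetamidocyclohexyl on a carbonyl carbon. Among the compounds with values here, no measured step touches the carbonyl carbon, so the account expects a step of no change at the digits printed from compound 2 to compound 3 (within the scatter) that stays within the scatter. For compound 3 the expected value in this assay is 3.5 uL/min, between 1 uL/min and 10 uL/min.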

Compound 3, intrinsic clearance in a liver preparation (reported as CLH), per the amount of preparation that the assay uses: 106 uL/min
Compound 3: middle estimate off by 30-fold (1.48 log units), on the low side; the whole stated range lies below it.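

In this assay the place on the carbonyl carbon proves far from silent: 3-hydroxycyclobutyl in place of 3-acetamidocyclohexyl gives a 30-fold higher number from compound 2 to compound 3 (1.48 log units; beyond the scatter) with the rest of the molecule unchanged. Going by these compounds alone, the read-out therefore responds to this place as well as to the group on the aromatic carbon, which the earlier compounds could not show. Nothing measured here gives a cause for this step. The ring and its substituent change together, and the compounds shown leave open which of them carries the step. A 3-hydroxycyclohexyl or a 3-acetamidocyclobutyl group on the same carbonyl carbon would separate the two.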